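Aryl Swap on a Semicarbazide Series: Compound 4

The source may hold more compounds than are shown below. What is called first, only, known or untested is meant among the compounds shown, and "the series" means these compounds.

In a functional assay on SW-620 cells (Homo sapiens) for inhibition, read by MTT assay, with a stated time of 72 h (on this read-out higher numbers stand for weaker inhibition and lower numbers for stronger inhibition), compound 1 `COc1cc(NC(C)CCCNC(=O)NNC(=O)Nc2cccc(F)c2)c2ncccc2c1` gives 9500 nM. Compound 2 `COc1cc(NC(C)CCCNC(=O)NNC(=O)Nc2cc(C(F)(F)F)cc(C(F)(F)F)c2)c2ncccc2c1` gives 16000 nM in this assay, a number within the scatter of that of compound 1. Compound 3 `COc1cc(NC(C)CCCNC(=O)Nc2ccc(F)cc2)c2ncccc2c1` gives 25000 nM, and the step of a 2.6-fold higher number from compound 1 to compound 3 (0.42 log units; beyond the scatter) is the only one in this set that rises beyond the scatter. Compound 4 `COc1cc(NC(C)CCCNC(=O)NNC(=O)Nc2ccc(Br)cc2)c2ncccc2c1` differs from compound 1 by 4-bromophenyl in place of 3-fluorophenyl on an amide-type nitrogen. For the measured compounds named here, no measured pair changes the aryl group on that nitrogen, so no step bears directly on this change, and none beyond the scatter is expected in this assay. The step of a 1.1-fold higher number from compound 1 to compound 4 (0.02 log units; within the scatter) is therefore expected to be small. Compound 4 is estimated at 10000 nM, with a range from 4000 nM to 25000 nM.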

Compound 4, half-maximal inhibitory concentration: 17000 nM
The estimate for compound 4 lay 1.7-fold (0.23 log units) below the measured number; the range from low to high includes it.
By their numbers in this assay, from the lowest: compounds 1, 2, 4 and 3 (each within the scatter of the next, the first and the last beyond it).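

Among the compounds shown, only the pair of compound 1 and compound 4 changes the aryl group on the amide-type nitrogen, and in this assay 4-bromophenyl in place of 3-fluorophenyl gives a 1.8-fold higher number from compound 1 to compound 4 (0.25 log units; within the scatter) at this position. The larger change of ((4-bromophenyl)carbamoyl)amino in place of 4-fluorophenyl gives a 1.5-fold lower number from compound 3 to compound 4 (0.17 log units; within the scatter) and so does not separate those two compounds either. No measurement available here accounts for either step.

On these data alone, it remains open whether an amine or a carboxylic acid on this aryl ring would move the number beyond the scatter. As far as these compounds go, the effect of a longer chain in place of the 4-bromophenyl group is also open.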